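Swapping a pentyl chain for a phenyl ring on the shared core

A few compounds are considered here, and "the series" means these few. Any claim that something is new, unique, unknown or untested is made for them only; others in the source may bear on it.

Compound 1, `Cc1ccccc1CNC(=O)n1c(N)nc2ccccc21`, gives 68.4 nM in an assay on HEK293 cells for inhibition of acid ceramidase (Homo sapiens), read by fluorescence, with stated times of 30 min and 1 h; on this read-out lower numbers stand for stronger inhibition and higher numbers for weaker inhibition.
Compound 2, `CCCCCCNC(=O)n1c(N)nc2ccccc21`, gives 2.4 nM in this assay.

Among the compounds with values here, of the two numbers measured so far, compound 2 holds the lower one, and the only step known, a 29-fold lower number from compound 1 to compound 2 (1.45 log units; beyond the scatter), links it to compound 1 and lies well beyond the scatter. Compound 3, `Nc1nc2ccccc2n1C(=O)NCc1ccccc1`, is the next compound in line for this assay. It differs from compound 2 by phenyl in place of pentyl on a saturated chain carbon bound to an amide-type nitrogen. Within the data shown here, the one measured step bears on this directly, since it is the change from compound 1 to compound 2 run nearly in reverse, only without the methyl on the ring: an aromatic ring standing in for the pentyl chain. That step was large, so a return toward the weaker end is expected for compound 3, though the missing methyl leaves room for a smaller move. The expected step is a 13-fold higher number from compound 2 to compound 3 (1.10 log units; beyond the scatter). Compound 3 is therefore estimated at 30 nM, within a range from 8 nM to 120 nM.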

Compound 3, half-maximal inhibitory concentration: 29.3 nM
Compound 3: the middle estimate sits 1.0-fold (0.01 log units) above what was measured; measured number inside the range.
By their numbers in this assay, from the lowest: compound 2; then compound 3; then compound 1.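

In this assay, phenyl in place of pentyl on a saturated chain carbon bound to an amide-type nitrogen gives a 12-fold higher number from compound 2 to compound 3 (1.09 log units; beyond the scatter) and so shows that the large move seen earlier also occurs without the methyl group carried by compound 1. Hydrogen in place of that methyl on an aromatic carbon gives a 2.3-fold lower number from compound 1 to compound 3 (0.37 log units; beyond the scatter) as a modest step that lies beyond the scatter, yet it is much smaller than the move between pentyl and phenyl, so among these three compounds the choice between chain and ring goes with most of the difference. The data offer no independent measurement that could explain why either change shifts the number.

A cyclohexyl group at this position would help show whether the weaker number goes with a ring as such or with an aromatic ring specifically, while a butyl or heptyl chain would show how closely the low number of compound 2 depends on chain length. As far as these compounds go, it also remains open whether a chlorine or methoxy group on the phenyl ring would move the number in the same direction as the methyl.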